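Shortening the Chain of a Shared Amide Core

This account rests on a few compounds, and the source may have more. Where it says the series, first, only, none or still open, it means among the compounds named here.

Two amides built on a shared core have been tested in a functional assay on HEK293 cells with transient receptor potential cation channel subfamily V member 1 (Homo sapiens) as the target; on this read-out lower numbers stand for an effect already at smaller amounts and higher numbers for an effect only at larger amounts of compound. Compound 1 `CCCCCCCCC#CCCCCCCCC(=O)NCc1ccc(O)c(OC)c1` gives 12.6 nM, and compound 2 `CCCCCC[C@@H](O)CCCCCCCCCCC(=O)NCc1ccc(O)c(OC)c1` gives 5.01 nM, the lowest of the two numbers, with compound 1 the nearest at a higher number beyond the usual scatter. Compound 3 `COc1cc(CNC(=O)CCCCCCCCC2CC2)ccc1O` differs from compound 2 by cyclopropyl in place of 3-hydroxynonyl on a saturated chain carbon, eight bonds along the chain from a carbonyl carbon. Among the measured compounds shown here, no measured pair isolates this change, so the expectation rests on the two values alone. Compound 3 is expected to need a larger amount, a step of a 12-fold higher number from compound 2 to compound 3 (1.08 log units; beyond the scatter) beyond the scatter, with an estimated value in this assay of 60 nM, between 15 nM and 300 nM.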

Compound 3, half-maximal effective concentration: 3.16 nM
Estimate against measurement, compound 3: 19-fold (1.28 log units) above; the measured number lies below the stated range.
By their numbers in this assay, from the lowest: compounds 3 and 2 (each within the scatter of the next); then compound 1.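

In this assay, cyclopropyl in place of 3-hydroxynonyl gives a 1.6-fold lower number from compound 2 to compound 3 (0.20 log units; within the scatter). At this place on the chain, then, a group of 3 heavy atoms with no hydrogen-bond donor or defined stereocentre gives a number that cannot be told apart from that of the group of 10 heavy atoms. Cyclopropylmethyl in place of dec-1-yn-1-yl gives a 4.0-fold lower number from compound 1 to compound 3 (0.60 log units; beyond the scatter), a modest step, and nothing measured here explains either result. Still open, from the compounds shown here alone, is whether a carboxylic acid or an amine at this chain end would give a similar number, and how a longer chain ending in cyclopropyl would compare.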